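Lengthening the Amide Chain on a Cyano Analogue

The compounds below may be only part of what the source reports. "The series", "measured", "known", "first", "only" and "open" are said of these compounds alone.

Compound 1 `CC/C=C/C(=O)Nc1cccc(Oc2nc(Nc3cccc(OC)c3)nc3c2CSCC3)c1` and compound 2 `CCC/C=C/C(=O)Nc1cccc(Oc2nc(Nc3cccc(OC)c3)nc3c2CSCC3)c1` share one core and differ only by methyl in place of hydrogen on a saturated chain carbon, two bonds along the chain from a double-bonded chain carbon. In a functional assay on A549 cells (Homo sapiens) for antiproliferative activity, read by MTT assay, with a stated time of 72 h (a higher number here means a weaker inhibitor, a lower number a stronger inhibitor), compound 1 gives 17200 nM, while compound 2 gives 11800 nM, which is a step of a 1.5-fold lower number from compound 1 to compound 2 (0.16 log units; within the scatter). Compound 3 `CC/C=C/C(=O)Nc1cccc(Oc2nc(Nc3cccc(C#N)c3)nc3c2CSCC3)c1` has a core that differs from that of compound 1 by cyano in place of methoxy on an aromatic carbon, and in this assay compound 3 gives 10100 nM, a step of a 1.7-fold lower number from compound 1 to compound 3 (0.23 log units; within the scatter). Compound 4 `CCC/C=C/C(=O)Nc1cccc(Oc2nc(Nc3cccc(C#N)c3)nc3c2CSCC3)c1` has not been measured yet. It differs from compound 3 by methyl in place of hydrogen on a saturated chain carbon, two bonds along the chain from a double-bonded chain carbon, the same change that was made from compound 1 to compound 2. The step in this assay is expected to be small, about a 1.3-fold lower number from compound 3 to compound 4 (0.10 log units; within the scatter), because the same change on the other core gave a 1.5-fold lower number from compound 1 to compound 2 (0.16 log units; within the scatter). For compound 4 the estimated value is 8000 nM, expected to lie between 4000 nM and 16000 nM.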

Compound 4, half-maximal inhibitory concentration: 5790 nM
Compound 4: middle estimate off by 1.4-fold (0.14 log units), on the high side, within the range that was stated.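

In this assay, going from but-1-en-1-yl to pent-1-en-1-yl on the cyano core gives a 1.7-fold lower number from compound 3 to compound 4 (0.24 log units; within the scatter), and this step agrees with the one on the methoxy core: the same change on two cores in this assay, a 1.5-fold lower number (0.16 log units; within the scatter) from compound 1 to compound 2 and a 1.7-fold lower number (0.24 log units; within the scatter) from compound 3 to compound 4, 1.2-fold (0.08 log units) apart, within the scatter of two such steps.
Putting cyano in place of methoxy on the longer chain gives a 2.0-fold lower number from compound 2 to compound 4 (0.31 log units; beyond the scatter), a modest step just beyond the scatter, and it agrees with the same swap on the shorter chain: the same change on two cores in this assay, a 1.7-fold lower number (0.23 log units; within the scatter) from compound 1 to compound 3 and a 2.0-fold lower number (0.31 log units; beyond the scatter) from compound 2 to compound 4, 1.2-fold (0.08 log units) apart, within the scatter of two such steps.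
Each change therefore carried over between these two cores at a similar size, but four compounds in a single assay do not show that this holds for other cores or other changes.

On these data alone, it remains open whether a longer chain on the amide would continue this course. The same is true of an amine or a carboxylic acid in place of the nitrile.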